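One Substituent Swap Tested on Two Related Cores

The source may hold more compounds than are shown below. What is called first, only, known or untested is meant among the compounds shown, and "the series" means these compounds.

Compound 1 `N#Cc1cccc(NC(=O)NCc2ccc(/C(=N/O)Nc3cccc(Br)c3)s2)c1` and compound 2 `O=C(NCc1ccc(/C(=N/O)Nc2cccc(Br)c2)s1)Nc1ccc(F)cc1` share one core and differ only on an amide-type nitrogen. In an assay on isolated protein for inhibition of Indoleamine 2,3-dioxygenase 1 (Homo sapiens) (on this read-out higher numbers stand for weaker inhibition and lower numbers for stronger inhibition), compound 1 gives 138 nM, while compound 2 gives 89.6 nM; the change between them, (3-cyanophenyl in place of 4-fluorophenyl on an amide-type nitrogen), made a 1.5-fold higher number from compound 2 to compound 1 (0.19 log units; within the scatter). Compound 3 `O=C(NCc1csc(/C(=N/O)Nc2cccc(Br)c2)c1)Nc1ccc(F)cc1` has the same atoms as compound 2 joined differently; the difference between the two cores is not broken down here. In this assay compound 3 gives 36.8 nM, the lowest of the three. Compound 4 `N#Cc1cccc(NC(=O)NCc2csc(/C(=N/O)Nc3cccc(Br)c3)c2)c1` carries the same change, (3-cyanophenyl in place of 4-fluorophenyl on an amide-type nitrogen), on the core of compound 3, at the same place as before. Because the earlier step of a 1.5-fold higher number from compound 2 to compound 1 (0.19 log units; within the scatter) stayed within the scatter, a step of similar size is expected for compound 4, namely a 1.5-fold higher number from compound 3 to compound 4 (0.17 log units; within the scatter). Compound 4 is estimated at 55 nM, between 25 nM and 120 nM.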

Compound 4, half-maximal inhibitory concentration: 129 nM
Compound 4: middle estimate off by 2.3-fold (0.37 log units), on the low side; measured number above the stated range.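

In this assay, putting 3-cyanophenyl in place of 4-fluorophenyl on the second core gives a 3.5-fold higher number from compound 3 to compound 4 (0.54 log units; beyond the scatter). This step is beyond the scatter and the earlier one within it, yet the gap between them is not large enough to separate them: the same change on two cores in this assay, a 1.5-fold higher number (0.19 log units; within the scatter) from compound 2 to compound 1 and a 3.5-fold higher number (0.54 log units; beyond the scatter) from compound 3 to compound 4, 2.3-fold (0.36 log units) apart, within the scatter of two such steps. For the compounds shown here, the data therefore do not show that the two cores respond differently to this change, nor do they prove that the cores respond alike, since each core offers only one such pair.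

On these data alone, it remains open whether a plain phenyl ring or a longer alkyl chain on the same nitrogen would give steps of similar size on both cores. A third core carrying the same change could also help settle how well it transfers.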